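Changing the outer aromatic ring on a citrate-like chain

The compounds below may be only part of what the source reports. "The series", "measured", "known", "first", "only" and "open" are said of these compounds alone.

Measured so far:
compound 1, `O=C(O)C[C@](O)(C(=O)O)[C@@H](O)CCCCCCCc1ccc(Cl)cc1Cl`, 5700 nM
compound 2, `Cc1ccc(-c2cc(Cl)ccc2CCCCCC[C@@H](O)C[C@](O)(CC(=O)O)C(=O)O)cc1`, 2700 nM

Of the compounds shown here, two have been tested in an assay on isolated protein for inhibition of ATP-citrate synthase (Homo sapiens); a higher number here means a weaker inhibitor, a lower number a stronger inhibitor. Compound 1, `O=C(O)C[C@](O)(C(=O)O)[C@@H](O)CCCCCCCc1ccc(Cl)cc1Cl`, carries a 2,4-dichlorophenyl group at the end of its chain and gives 5700 nM. Compound 2, `Cc1ccc(-c2cc(Cl)ccc2CCCCCC[C@@H](O)C[C@](O)(CC(=O)O)C(=O)O)cc1`, carries a 4-methylphenyl group on its outer aromatic ring and gives 2700 nM, the lower of the two numbers; its gap to compound 1 lies beyond the usual scatter.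

Compound 3, `O=C(O)C[C@@](O)(C[C@H](O)CCCCCCc1ccc(Cl)cc1-c1ccc(Cl)cc1Cl)C(=O)O`, has not yet been measured. It differs from compound 2 in one place: 2,4-dichlorophenyl in place of 4-methylphenyl on an aromatic carbon. The change sits on an aromatic carbon of a six-membered aromatic ring of carbon only, ortho to a large group and meta to a chloro group.

Within the data shown here, no pair of measured compounds separated by a single change exists here, so no step size can be read off. Compound 3 is expected to land close to compound 2, with a step of a 1.1-fold lower number from compound 2 to compound 3 (0.03 log units; within the scatter) that is not expected to exceed the scatter in either direction. The estimate for compound 3 in this assay is 2500 nM, within a range from 900 nM to 7000 nM.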

Compound 3, inhibition constant: 21000 nM
For compound 3 the middle estimate is 8.4-fold (0.92 log units) below the measured one; measured number above the stated range.
By their numbers in this assay, from the lowest: compound 2; then compound 1; then compound 3.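

In this assay, putting 2,4-dichlorophenyl in place of 4-methylphenyl on this aromatic carbon, ortho to a large group and meta to a chloro group, gives a 7.8-fold higher number from compound 2 to compound 3 (0.89 log units; beyond the scatter), so this position is not indifferent to what the outer ring carries. The change looks small on paper: each group is one six-membered aromatic ring of carbon only, with 0 hydrogen-bond donors, 0 hydrogen-bond acceptors and no net charge, and the count goes only from 7 heavy atoms to 8, yet the step lies beyond the scatter. Nothing measured here explains why the number rises with this swap.

This one swap removes a methyl group and brings in two chlorines at once, so the compounds shown cannot separate the loss of the methyl from the gain of either chlorine. A plain phenyl ring or a phenyl ring carrying a single chlorine at this carbon would be needed to tell which part of the change goes with the weaker binding.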